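A furan swap on compound 1

The compounds below may be only part of what the source reports. "The series", "measured", "known", "first", "only" and "open" are said of these compounds alone.

Compound 1 `CC(C)c1[nH]cnc1/C=c1\[nH]c(=O)/c(=C/c2cccc(Oc3ccc(F)cc3)c2)[nH]c1=O`: 3.7 nM
Compound 2 `CC(C)c1[nH]cnc1/C=c1\[nH]c(=O)/c(=C/c2cccc(C(=O)c3ccc(F)cc3)c2)[nH]c1=O`: 0.8 nM
Compound 3 `Cc1ccc(/C=c2\[nH]c(=O)/c(=C/c3cccc(C(=O)c4ccc(F)cc4)c3)[nH]c2=O)o1`: 3.3 nM

These values come from a functional assay on HT-29 cells (Homo sapiens) for cytotoxicity, read by MTT assay, with a stated time of 72 h; on this read-out lower numbers stand for stronger inhibition and higher numbers for weaker inhibition. The values of compound 1 and compound 3 lie within the usual scatter of each other, and compound 2 stands clearly lower, with a 4.6-fold lower number from compound 1 to compound 2 (0.67 log units; beyond the scatter). That step changes another part of the molecule, so it offers little guidance here.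

Compound 4 `COCc1ccc(/C=c2\[nH]c(=O)/c(=C/c3cccc(Oc4ccc(F)cc4)c3)[nH]c2=O)o1` differs from compound 1 in one group: 5-(methoxymethyl)furan-2-yl in place of 5-isopropyl-1H-imidazol-4-yl on a double-bonded chain carbon bound to an aromatic carbon. The closest guide is the similar swap to 5-methylfuran-2-yl, which gave a 4.1-fold higher number from compound 2 to compound 3 (0.62 log units; beyond the scatter). Among the measured compounds shown here, no measured compound carries the 5-(methoxymethyl)furan-2-yl group, so a rise of similar size is expected only loosely. The estimated change is a 3.8-fold higher number from compound 1 to compound 4 (0.58 log units; beyond the scatter). For compound 4, the expected value is 14 nM, within an estimated range of 4 nM to 50 nM.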

Compound 4, half-maximal inhibitory concentration: 7 nM
For compound 4 the middle estimate is 2.0-fold (0.30 log units) above the measured one, within the range that was stated.
By their numbers in this assay, from the lowest: compound 2; then compounds 3, 1 and 4 (each within the scatter of the next, the first and the last beyond it).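

Replacing 5-isopropyl-1H-imidazol-4-yl with 5-(methoxymethyl)furan-2-yl gives a 1.9-fold higher number from compound 1 to compound 4 (0.28 log units; within the scatter), so with the 4-fluorophenoxy group in place, this furan can stand on the double-bonded chain carbon without a change that exceeds the scatter. The earlier swap to 5-methylfuran-2-yl gave a 4.1-fold higher number from compound 2 to compound 3 (0.62 log units; beyond the scatter), but it differs in both the furan group and the rest of the molecule. Nothing available explains this result.

From the compounds shown here alone, it remains open whether the outcome depends on the furan's substituent or on the 4-fluorophenoxy group. Going by these compounds, how a furan carrying an amine or a carboxylic acid would behave also remains open.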